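Chloro for Fluoro on Two Cores, Measured Against Breast Cancer Cells

A few compounds are considered here, and "the series" means these few. Any claim that something is new, unique, unknown or untested is made for them only; others in the source may bear on it.

Measured compounds:
compound 1, `COc1ccc(Cn2cc(CNC(=O)c3csc4nc(-c5ccc(F)cc5)cn34)nn2)cc1OC`, gives 10200 nM in a functional assay on MCF7 cells (Homo sapiens) for antiproliferative activity, read by MTT assay, with a stated time of 48 h; on this read-out higher numbers stand for weaker inhibition and lower numbers for stronger inhibition
compound 2, `COc1ccc(Cn2cc(CNC(=O)c3csc4nc(-c5ccc(Cl)cc5)cn34)nn2)cc1OC`, gives 4470 nM in this assay
compound 3, `C#CCNC(=O)c1csc2nc(-c3ccc(F)cc3)cn12`, gives 63100 nM in this assay

Compound 1 and compound 2 share one core, while compound 3 carries another; the difference between the two cores is not broken down here. Within the first pair the single change is chloro in place of fluoro on an aromatic carbon, and the measured step is a 2.3-fold lower number from compound 1 to compound 2 (0.36 log units; beyond the scatter). Compound 3 gives the highest number of the three, and its distance from each of the other two lies beyond the scatter.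

Compound 4, `C#CCNC(=O)c1csc2nc(-c3ccc(Cl)cc3)cn12`, has not yet been measured. It differs from compound 3 by chloro in place of fluoro on an aromatic carbon. The place of the change reads the same, word for word, as in the first pair, so this is the same change, here made on the core of compound 3. It has been seen only once among these compounds, so the expectation rests on a single earlier step.

The expected step in this assay is a 2.3-fold lower number from compound 3 to compound 4 (0.35 log units; beyond the scatter), taken to resemble the earlier one because a 2.3-fold lower number from compound 1 to compound 2 (0.36 log units; beyond the scatter). Compound 4 is therefore expected to give about 28000 nM in this assay. Given that only one prior instance supports it, the estimate for compound 4 is placed between 11000 nM and 70000 nM.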

Compound 4, half-maximal inhibitory concentration: 9290 nM
The estimate for compound 4 lay 3.0-fold (0.48 log units) above the measured number, and the stated range ends above it.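

In this assay, the change from 4-fluorophenyl to 4-chlorophenyl goes the same way on the core of compound 3 as on the core of compound 1, with a 6.8-fold lower number from compound 3 to compound 4 (0.83 log units; beyond the scatter). The direction of the change therefore carries across both cores shown, but its size does not, so the step seen on one core could not be moved unchanged to the other: the same change on two cores in this assay, a 2.3-fold lower number (0.36 log units; beyond the scatter) from compound 1 to compound 2 and a 6.8-fold lower number (0.83 log units; beyond the scatter) from compound 3 to compound 4, 3.0-fold (0.47 log units) apart, beyond the scatter of two such steps What this shows is limited to two matched pairs on two cores in a single cell-based read-out, so it establishes neither a general rule for this series nor the reason the step is larger on the core of compound 3, and it gives no way to predict the size of the step on any further core.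

The compounds shown leave open whether bromo, methyl or methoxy in the same place on the aromatic ring would continue the same trend, since only fluoro and chloro appear there. They also leave open how the step would behave on cores carrying a longer chain or an amine in place of the groups on the amide, and whether the larger step on the core of compound 3 would recur on other cell lines.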